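Working notes: replacing chloro in compound 3

The compounds below may be only part of what the source reports. "The series", "measured", "known", "first", "only" and "open" are said of these compounds alone.

Measured so far in a toxicity assay on CCRF-CEM cells (Homo sapiens) for cytotoxicity; on this read-out lower numbers stand for higher toxicity in this test and higher numbers for lower toxicity in this test
compound 1 `CCc1cccc2c1nc(-c1c(F)cccc1F)n2Cc1c(F)cccc1F` gives 26.1 uM
compound 2 `COC(=O)c1cccc2c1nc(-c1c(F)cccc1F)n2Cc1c(F)cccc1F` gives 57.7 uM
compound 3 `Fc1cccc(F)c1Cn1c(-c2c(F)cccc2F)nc2c(Cl)cccc21` gives 30.4 uM
compound 4 `CC(=O)N(C)c1cccc2c1nc(-c1c(F)cccc1F)n2Cc1c(F)cccc1F` is not yet measured

Compound 3 sits within the usual scatter of both other compounds, with a 1.2-fold higher number from compound 1 to compound 3 (0.07 log units; within the scatter) and a 1.9-fold lower number from compound 2 to compound 3 (0.28 log units; within the scatter) on record. Only a 2.2-fold higher number from compound 1 to compound 2 (0.34 log units; beyond the scatter) lies beyond the scatter, and that step is modest.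

Compound 4 carries acetyl(methyl)amino in place of chloro on an aromatic carbon. Among the measured compounds shown here, no measured compound holds this group, so the three measured steps are the only guide, and none of them is large. Chloro, ethyl and methoxycarbonyl at this place all leave the numbers close together, which makes a large step unlikely. For the measured compounds named here, compound 2, the one measured compound whose group also contains a carbonyl, gives 57.7 uM in this series, so a small rise is the likelier direction. In this assay the expected step is a 1.3-fold higher number from compound 3 to compound 4 (0.12 log units; within the scatter) and it is not expected to pass the scatter. For compound 4 the estimated value is 40 uM with an expected range from 18 uM to 90 uM on this read-out.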

Compound 4, half-maximal toxic concentration: > 100 uM
Compound 4 was reported as a limit (the forecaster's own chance of this, stated with the estimate: 15%); middle value at least 2.5-fold (0.39 log units) away from the limit.
By their numbers in this assay, from the lowest: compounds 1, 3 and 2 (each within the scatter of the next, the first and the last beyond it). At a limit, above all of these: compound 4.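

Working notes on this position: in this assay ethyl, chloro and methoxycarbonyl on this aromatic carbon left the numbers close together, with modest steps at most. Acetyl(methyl)amino in place of chloro gives an at least 3.2-fold higher number from compound 3 to compound 4 (0.51 log units; beyond the scatter) and in place of ethyl gives an at least 3.8-fold higher number from compound 1 to compound 4 (0.58 log units; beyond the scatter), so this place can carry a larger change in the number than the earlier groups showed. Against methoxycarbonyl the record is an at least 1.7-fold higher number from compound 2 to compound 4 (0.23 log units; that floor lies within the scatter) and that floor alone does not set the two groups apart, while a carbonyl in the group goes with the numbers furthest from compound 1 in compound 2 and compound 4, but compound 2 stays within the scatter of compound 3, so this link rests mainly on compound 4.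

Open, going by these compounds, is what a primary amine, a carboxylic acid or the amide with its hydrogen in place of the nitrogen methyl would give at this place, and whether the acetyl part or the nitrogen goes with the change. How far compound 4 lies from the others also stays open, as its entry is a limit and not a number: the limit of > 100 uM in this assay, at which 1 of the 4 values shown sits.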